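A few compounds are considered here, and "the series" means these few. Any claim that something is new, unique, unknown or untested is made for them only; others in the source may bear on it.

Working notes on the series in a functional assay on MGC-803 cells (Homo sapiens) for antiproliferative activity, read by CCK-8 assay, with a stated time of 72 h; a lower number here means a stronger inhibitor, a higher number a weaker inhibitor. Compound 1 `Nc1ccccc1NC(=O)c1ccc(COc2ccc(Br)cc2)cc1` reaches only the assay limit there, giving > 32000 nM. Compound 3 `Nc1cnccc1NC(=O)/C=C/c1ccc(COc2ccccc2)cc1` likewise stops at the assay limit, with > 32000 nM. For compound 2 `O=C(/C=C/c1ccc(CN2CCc3ccccc32)cc1)NO` the entry in this assay reads "not determined" (no result reported), so no number is known for it. Among the compounds with values here, compound 1 thus stands on a limit rather than on a value, and two of the three entries sit at that limit (the limit of > 32000 nM in this assay, at which 2 of the 3 values shown sit); the values shown do not separate compound 1 from compound 3, and no step between measured compounds has been worked out, so there is no measured change on which to lean.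

Compound 4 `CC(C)c1ccc(OCc2ccc(C(=O)Nc3ccccc3N)cc2)cc1` is to be measured in this assay. It differs from compound 1 in one place: isopropyl in place of bromo on an aromatic carbon. The change keeps the shared core of compound 1 and swaps only the substituent on the far aromatic ring. Since compound 1 gives only the limit > 32000 nM, the expectation for compound 4 is set at that limit as well. The step expected a step that the limit leaves unreadable from compound 1 to compound 4 is none beyond the usual scatter. Compound 4 is therefore estimated to come out near 40000 nM, within 10000 nM to 120000 nM, and most probably again reported as a limit.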

Compound 4, half-maximal inhibitory concentration: > 32000 nM
Compound 4: a limit, no number (the forecaster's own chance of this, stated with the estimate: 70%); the middle value does not contradict the limit.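

Compound 1 and compound 4 both stop at a limit in this assay, so no step can be read for isopropyl in place of bromo on an aromatic carbon: the limit of > 32000 nM in this assay, at which 3 of the 4 values shown sit.

The compounds shown leave open whether any substituent at this place on the shared core would give a measured number in this assay rather than a limit.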